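Hydroxamic Acids on a Shared Core: Toward a Bromobenzyl Analogue

A few compounds are considered here, and "the series" means these few. Any claim that something is new, unique, unknown or untested is made for them only; others in the source may bear on it.

Measured compounds:
- compound 1 `O=C(CCC1=CCCN(CCCCc2ccc(-c3ccccc3)cc2)C1=O)NO`: 2670 nM
- compound 3 `O=C(CCC1=CCCN(CCCc2ccc(-c3ccccc3)cc2)C1=O)NO`: 2490 nM
- compound 2 `CC(=O)Nc1ccc(CN2CCC=C(CCC(=O)NO)C2=O)cc1`: "not determined" (no result reported)

Compound 1 and compound 3 carry the same core and differ only in the length of the chain to the biphenyl group. In a functional assay on ACHN cells (Homo sapiens) for inhibition, read by sulforhodamine B assay (a lower number here means a stronger inhibitor of growth, a higher number a weaker inhibitor of growth), compound 1 gives 2670 nM and compound 3 gives 2490 nM; the two values lie within the usual scatter of each other, so neither can be called the stronger of the pair. Compound 2 keeps the same core but bears a benzyl substituent with an acetamido group; for compound 2 the result in this assay is "not determined" (no result reported), so it stands nowhere on the numbers shown and offers no anchor of its own.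

Compound 4 `O=C(CCC1=CCCN(Cc2ccc(Br)cc2)C1=O)NO` is the next compound. Relative to compound 2 the change is bromo in place of acetamido on an aromatic carbon. Going by the values given here, since no pair of measured compounds differing in one place is available, the size of this step in this assay is unknown; the only guidance is that the two measured analogues, with much larger substituents, both fall near the same value. Compound 4 is therefore expected to land in a similar region, with wide uncertainty in either direction: an estimated 3000 nM, between 700 nM and 13000 nM.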

Compound 4, concentration for 50% growth inhibition: 2480 nM
Compound 4: the middle estimate sits 1.2-fold (0.08 log units) above what was measured, and the stated range covers the measured number.
By their numbers in this assay, from the lowest: compounds 4, 3 and 1 (each within the scatter of the next).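

Compound 4 yields no readable step: its one-place partner, compound 2, carries no number in this assay. The compounds shown leave open how far replacing acetamido with bromo on the shared core shifts growth inhibition. No measured evidence bears on the cause of the result for compound 4.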